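The compounds below may be only part of what the source reports. "The series", "measured", "known", "first", "only" and "open" are said of these compounds alone.

Measured compounds:
- compound 1, `O=C(Nc1ccc(NCC2CC2)cc1Cl)c1cc(Cl)ccc1O`: 14400 nM
- compound 2, `O=C(Nc1ccc(NCc2ccc(O)cc2)cc1Cl)c1cc(Cl)ccc1O`: 116000 nM

Both compounds were tested in an ADME assay on A549 cells (Homo sapiens) for cytotoxicity, read by resazurin assay, with a stated time of 48 h; on this read-out higher numbers stand for lower toxicity in this test and lower numbers for higher toxicity in this test. Compound 2 gives the higher of the two numbers, and its step from compound 1 is an 8.1-fold higher number from compound 1 to compound 2 (0.91 log units; beyond the scatter), so compound 2 is the less toxic of the pair in this assay.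

Compound 3, `O=C(Nc1ccc(NCCCO)cc1Cl)c1cc(Cl)ccc1O`, has not yet been measured. It differs from compound 2 in one place: 2-hydroxyethyl in place of 4-hydroxyphenyl on a saturated chain carbon bound to a nitrogen on an aromatic ring. Among the measured compounds shown here, the only step that bears on this change is the one from compound 1 to compound 2, where a small saturated group gave way to an aromatic one; that was a modest step, beyond the scatter. Here the aromatic group departs again and a short chain takes its place, so a step back downward seems the more likely outcome, though its size is uncertain. The expected step is a 2.3-fold lower number from compound 2 to compound 3 (0.37 log units; beyond the scatter). Compound 3 is therefore estimated at 50000 nM, in a range from 15000 nM to 160000 nM.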

Compound 3, half-maximal cytotoxic concentration: 106000 nM
Compound 3: middle estimate off by 2.1-fold (0.33 log units), on the low side; the range from low to high includes it.
By their numbers in this assay, from the lowest: compound 1; then compounds 3 and 2 (each within the scatter of the next).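

In this assay, replacing 4-hydroxyphenyl, with its aromatic ring and 7 heavy atoms, by 2-hydroxyethyl, with no ring and 3 heavy atoms, gives a 1.1-fold lower number from compound 2 to compound 3 (0.04 log units; within the scatter), so at this position an aromatic ring is not needed to keep the number at the level of compound 2. The other comparison gives a 7.4-fold higher number from compound 1 to compound 3 (0.87 log units; beyond the scatter), which shows that the high number in this small set is not unique to the ring-bearing group: two very different hydroxyl-bearing groups both stand clear of cyclopropyl. No measurement shown here explains this result.

The compounds shown leave open whether the hydroxyl itself matters, which a plain propyl chain or an unsubstituted benzyl group would test. They also leave open how an amine or a carboxylic acid in place of that hydroxyl would read.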